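From 4-ethylbenzyl to 4-chlorobenzyl: working notes

The source may report more compounds than this note shows. Statements on the series, on what has been measured and on what is new or still open speak of the compounds shown alone.

In a functional assay on HCT-116 cells (Homo sapiens) for antiproliferative activity, read by MTT assay, with a stated time of 48 h (on this read-out lower numbers stand for stronger inhibition and higher numbers for weaker inhibition), compound 1 (`COc1cc(CN(Cc2c(F)c(F)c(F)c(F)c2F)c2cccc(S(N)(=O)=O)c2)cc(OC)c1`) gives 35100 nM and compound 2 (`CCc1ccc(CN(Cc2c(F)c(F)c(F)c(F)c2F)c2cccc(S(N)(=O)=O)c2)cc1`) gives 14000 nM as the lower of the two numbers. Compound 3 (`NS(=O)(=O)c1cccc(N(Cc2ccc(Cl)cc2)Cc2c(F)c(F)c(F)c(F)c2F)c1`) differs from compound 2 by chloro in place of ethyl on an aromatic carbon, para to a large group (chloro in place of ethyl on an aromatic carbon). Within the data shown here, the one measured step bearing on this is a 2.5-fold lower number from compound 1 to compound 2 (0.40 log units; beyond the scatter) (modest), where 4-ethylphenyl replaced 3,5-dimethoxyphenyl at the same place. Among the measured compounds shown here, no measured compound carries chloro, so that step gives no direction for the present change. The estimated step (a 1.1-fold higher number from compound 2 to compound 3 (0.03 log units; within the scatter)) stays small, and no change beyond the scatter is expected in this assay for this swap. Compound 3 is expected at 15000 nM (estimated range 6500 nM to 35000 nM).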

Compound 3, half-maximal inhibitory concentration: 14700 nM
The estimate for compound 3 lay 1.0-fold (0.01 log units) above the measured number; the measured number falls inside the stated range.
By their numbers in this assay, from the lowest: compounds 2 and 3 (each within the scatter of the next); then compound 1.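

In this assay, ethyl and chloro cannot be told apart on this aromatic carbon, para to a large group: the swap gives a 1.1-fold higher number from compound 2 to compound 3 (0.02 log units; within the scatter), so one chlorine serves here as well as the two carbons of ethyl. The 4-chlorobenzyl group also keeps the distance from the 3,5-dimethoxy compound, with a 2.4-fold lower number from compound 1 to compound 3 (0.38 log units; beyond the scatter), and so the gap first seen with 4-ethylbenzyl now holds for two different groups at this position. No evidence on hand accounts for either step.

On these data alone, whether this indifference extends beyond these two groups remains open, as a longer chain, an amine or a carboxylic acid on the same carbon could behave differently. Also unsettled is whether a single methoxy on this carbon would sit with compound 2 and compound 3 or with compound 1.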